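The source may report more compounds than this note shows. Statements on the series, on what has been measured and on what is new or still open speak of the compounds shown alone.

Measured compounds:
- compound 1, `CC(C)(C)n1ncc(OCc2nnc(-c3cccc(F)c3)o2)c(Cl)c1=O`, 7.1 ug/mL
- compound 2, `CC(C)(C)n1ncc(OCc2nnc(-c3cc(F)c(F)cc3F)o2)c(Cl)c1=O`, 75.7 ug/mL
- compound 3, `CCc1ccc(-c2nnc(COc3cnn(C(C)(C)C)c(=O)c3Cl)o2)cc1`, 14.5 ug/mL

In a functional assay on the whole organism for inhibition, with Mythimna separata as the target, with a stated time of 5 days (a lower number here means that less compound is needed, a higher number that more compound is needed for the effect), compound 3 stands second highest of the three numbers: its nearest neighbour is compound 1, with a 2.0-fold higher number from compound 1 to compound 3 (0.31 log units; beyond the scatter) separating them, and its furthest is compound 2, with a 5.2-fold lower number from compound 2 to compound 3 (0.72 log units; beyond the scatter). Compound 4, `CC(C)(C)n1ncc(OCc2nnc(-c3ccc(Cl)cc3F)o2)c(Cl)c1=O`, has not yet been measured. It differs from compound 3 by 4-chloro-2-fluorophenyl in place of 4-ethylphenyl on an aromatic carbon.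

Two of the measured steps speak to this change, both exchanging the ring on that position. Going from a single-fluorine ring to the ethyl ring gave a 2.0-fold higher number from compound 1 to compound 3 (0.31 log units; beyond the scatter), a modest shift, while going from the three-fluorine ring to the ethyl ring gave a 5.2-fold lower number from compound 2 to compound 3 (0.72 log units; beyond the scatter), a larger one. Compound 4 carries two halogens on its ring, between those two measured cases, so the step in this assay is expected to be modest and to go towards a higher number, though close to the scatter.

For compound 4 the expected value in this assay is 20 ug/mL, in a range from 6 ug/mL to 65 ug/mL, which is expected to mean a step of a 1.4-fold higher number from compound 3 to compound 4 (0.14 log units; within the scatter).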

Compound 4, half-maximal effective concentration: 10.4 ug/mL
Beside the measured number, compound 4's estimate is 1.9-fold (0.28 log units) above it; the measured number falls inside the stated range.
By their numbers in this assay, from the lowest: compounds 1, 4 and 3 (each within the scatter of the next, the first and the last beyond it); then compound 2.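

In this assay, the step from 4-ethylphenyl to 4-chloro-2-fluorophenyl on this aromatic carbon stays within the scatter (a 1.4-fold lower number from compound 3 to compound 4 (0.14 log units; within the scatter)), and so does the step from 3-fluorophenyl (a 1.5-fold higher number from compound 1 to compound 4 (0.17 log units; within the scatter)). Compound 2 stands clearly apart from the new compound (a 7.3-fold lower number from compound 2 to compound 4 (0.86 log units; beyond the scatter)), so a ring with two halogens groups with the one-fluorine and ethyl rings here, not with 2,4,5-trifluorophenyl, although three compounds with halogens on this ring are too few to make a rule. No measurement shown explains this difference.

From the compounds shown here alone, whether the chlorine or the fluorine of compound 4 matters more remains open, and a 4-chlorophenyl ring would help to separate them. Going by these compounds, how a methoxy group, an amine or a carboxylic acid on this ring would behave also remains open.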